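Methyl removal in two cores: working notes

The compounds below may be only part of what the source reports. "The series", "measured", "known", "first", "only" and "open" are said of these compounds alone.

Measured so far:
compound 1 `Cc1cnn(C(=O)N(C)CCN(C)C(c2ccc(OCc3ccccc3)cc2)c2ccc(OCc3ccccc3)cc2)c1`, > 1000000 nM
compound 2 `CN(CCN(C)C(c1ccc(OCc2ccccc2)cc1)c1ccc(OCc2ccccc2)cc1)C(=O)n1cccn1`, > 1000000 nM
compound 3 `Cc1cnn(C(=O)N2CCN(C(c3ccc(OCc4ccccc4)cc3)c3ccc(OCc4ccccc4)cc3)CC2)c1`, > 100000 nM

In an assay on membranes from brain for binding affinity to neutral cholesterol ester hydrolase 1 (Mus musculus), read by fluorescence, with stated times of 1 h and 30 min (a higher number here means a weaker inhibitor, a lower number a stronger inhibitor), compound 1 gives only a limit, > 1000000 nM. Compound 2 likewise gives only a limit, > 1000000 nM. Compound 3 gives only a limit, > 100000 nM. The change from compound 1 to compound 2 is hydrogen in place of methyl on an aromatic carbon; the step that the two limits leave unreadable from compound 1 to compound 2 cannot be read because both values sit at the limit of > 1000000 nM in this assay, at which 2 of the 3 values shown sit. Compound 4 `O=C(N1CCN(C(c2ccc(OCc3ccccc3)cc2)c2ccc(OCc3ccccc3)cc2)CC1)n1cccn1` is not yet measured; it differs from compound 3 by hydrogen in place of methyl on an aromatic carbon, the same change as from compound 1 to compound 2. The difference between the two cores is not broken down here. Given that compound 3 sits at the limit of > 100000 nM in this assay, at which 1 of the 3 values shown sits, compound 4 is expected to make the step that the limit leaves unreadable from compound 3 to compound 4, with a limit again the likely outcome. Compound 4 is estimated at 300000 nM in this assay, range 100000 nM to 1000000 nM.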

Compound 4, half-maximal inhibitory concentration: > 100000 nM
Compound 4: no number, only a limit; the forecaster's own chance of this, stated with the estimate: 90%; the middle value is on the limit's open side.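

Compound 3 and compound 4 both give only limits in this assay, so no step can be read between them: the limit of > 100000 nM in this assay, at which 2 of the 4 values shown sit.

The compounds shown leave open what size the change from 4-methyl-1H-pyrazol-1-yl to 1H-pyrazol-1-yl has in either core.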